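The compounds below may be only part of what the source reports. "The series", "measured", "known", "first", "only" and "open" are said of these compounds alone.

Of the compounds shown here, two have been measured in a physicochemical assay for solubility, in phosphate buffer, measured as thermodynamic solubility, at pH 7.4; on this read-out higher numbers stand for higher solubility and lower numbers for lower solubility. Compound 1, `CS(=O)(=O)NC(=O)CCc1cn(-c2ccccc2)nc1-c1ccc(Cl)cc1`, gives 200000 nM. Compound 2, `CN(C(=O)CCc1cn(-c2ccc(Br)cc2)nc1-c1ccc(Cl)cc1)S(C)(=O)=O`, returns only < 5000 nM, which is a limit of the measurement rather than a number. Compound 2 therefore sits at the limit of < 5000 nM in this assay, at which 1 of the 2 values shown sits, and its solubility cannot be placed more closely than that. The next compound is compound 3, `O=c1[nH]c(CCc2cn(-c3ccc(Br)cc3)nc2-c2ccc(Cl)cc2)no1`. Compared with compound 2 it carries a group of 6 heavy atoms (2 carbon, 2 nitrogen, 2 oxygen; one five-membered aromatic ring with 3 hetero atoms) in place of a group of 8 heavy atoms (3 carbon, 1 nitrogen, 3 oxygen, 1 sulfur; no ring), on a saturated chain carbon, two bonds along the chain from an aromatic carbon. Among the compounds with values here, no pair of measured compounds differs in this single way, so no measured step shows how this exchange acts on solubility. An upward step is expected from compound 2 to compound 3 of about an at least 6.0-fold higher number from compound 2 to compound 3 (0.77 log units; beyond the scatter), an estimate that rests only on compound 1 giving a clear number, 200000 nM. Compound 3 is accordingly expected to reach about 30000 nM, with a range from 5000 nM to 150000 nM.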

Compound 3, solubility: < 5000 nM
Compound 3 ended at the assay's limit; the forecaster's own chance of this, stated with the estimate: 25%; middle value at least 6.0-fold (0.77 log units) from the limit.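

Compound 2 and compound 3 both end at a limit of the measurement rather than a number, so no step can be read between them: the limit of < 5000 nM in this assay, at which 2 of the 3 values shown sit.

The compounds shown leave open whether exchanging the methyl(methylsulfonyl)carbamoyl group for the five-membered aromatic ring changes solubility at all.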